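Benzoyl in Place of a Nine-Atom Group: Expected Outcome

The source may hold more compounds than are shown below. What is called first, only, known or untested is meant among the compounds shown, and "the series" means these compounds.

Three compounds have been measured in a functional assay on the whole organism (strain albino) for inhibition, with Rattus norvegicus as the target, read by paw edema, with a stated time of 2 h, at a dose of 0.28 mmol/kg by the oral route; a higher number here means more inhibition at the dose given (going by the name of the read-out), a lower number less inhibition:
Compound 1 `CCn1c(SC/C(=N/O)c2ccccc2)nnc1-c1ccc(OC)c(OC)c1` gives 67%.
Compound 2 `C=CCn1c(SC/C(=N/O)c2ccccc2)nnc1-c1cc(OC)c(OC)c(OC)c1` gives 68%.
Compound 3 `CCn1c(SCC(=O)c2ccccc2)nnc1-c1ccc(OC)c(OC)c1` gives 55%.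

The difference between the cores of compound 1 and compound 2 is not broken down here; their two values lie within the usual scatter of each other. Compound 3 differs from compound 1 by a group of 8 heavy atoms (7 carbon, 1 oxygen; one six-membered aromatic ring of carbon only) in place of a group of 9 heavy atoms (7 carbon, 1 nitrogen, 1 oxygen; one six-membered aromatic ring of carbon only), on a saturated chain carbon bound to a sulfur, and this step was a number 12 percentage points lower from compound 1 to compound 3 (beyond the scatter).

Compound 4 `C=CCn1c(SCC(=O)c2ccccc2)nnc1-c1cc(OC)c(OC)c(OC)c1` has not yet been measured. Among the measured compounds shown here, it differs from compound 2 by a group of 8 heavy atoms (7 carbon, 1 oxygen; one six-membered aromatic ring of carbon only) in place of a group of 9 heavy atoms (7 carbon, 1 nitrogen, 1 oxygen; one six-membered aromatic ring of carbon only), on a saturated chain carbon bound to a sulfur, the same change at the same place as the one seen from compound 1 to compound 3. For the measured compounds named here, the step from compound 2 to compound 4 is expected to be a number 12 percentage points lower from compound 2 to compound 4 (beyond the scatter), which rests on the single earlier step that was a number 12 percentage points lower from compound 1 to compound 3 (beyond the scatter). Compound 4 is therefore expected to give 56% in this assay, with a likely range from 44% to 67%.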

Compound 4, a percentage reported as inhibition, in the whole organism at one dose (the size of the read-out at that dose, not a potency): 62%
Compound 4: middle estimate off by 6 percentage points, on the low side; low and high end bracket the measured number.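

On the core of compound 2, benzoyl in place of the group of 9 heavy atoms gave a number 6 percentage points lower from compound 2 to compound 4 (within the scatter). Set beside the earlier step, the change does not read differently on the two cores: the same change on two cores in this assay, a number 12 percentage points lower (beyond the scatter) from compound 1 to compound 3 and a number 6 percentage points lower (within the scatter) from compound 2 to compound 4, 6 percentage points apart, within the scatter of two such steps. Among the compounds shown here, this shows that the two steps can be treated as one result within the scatter, but it rests on only two pairs, and it does not show that the change lowers the number on the core of compound 2 taken alone.

The compounds shown leave open how an amine, a carboxylic acid or a longer chain would read in this assay on that same saturated chain carbon bound to a sulfur. They also leave open whether the step would hold on any core beyond these two.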